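The source may report more compounds than this note shows. Statements on the series, on what has been measured and on what is new or still open speak of the compounds shown alone.

Compound 2 `Fc1ccc(CCC2(F)CCN(CCCc3c[nH]c4ccc(-n5cnnc5)cc34)CC2)cc1` stands, in an assay on CHO cells for displacement of a labelled ligand from 5-hydroxytryptamine receptor 1D (Homo sapiens) (a higher number here means a weaker inhibitor, a lower number a stronger inhibitor), at 1 nM; compound 1 `Fc1cccc(CCC2(F)CCN(CCCc3c[nH]c4ccc(-n5cnnc5)cc34)CC2)c1` gives 0.7 nM, and the step of a 1.4-fold higher number from compound 1 to compound 2 (0.15 log units; within the scatter) lies within the scatter, so compound 2 stands level with compound 1 on the two numbers shown. The next compound, compound 3 `CC(CC1(F)CCN(CCCc2c[nH]c3ccc(-n4cnnc4)cc23)CC1)c1ccccc1`, differs from compound 2 by 1-phenylethyl in place of 4-fluorobenzyl on a saturated chain carbon bound to a saturated ring carbon. Going by the values given here, no measured step bears directly on this change: the only step in hand, a 1.4-fold higher number from compound 1 to compound 2 (0.15 log units; within the scatter), exchanges 3-fluorophenyl for 4-fluorophenyl and leaves the chain untouched, whereas here the 4-fluorobenzyl leaves and 1-phenylethyl enters on the chain carbon bound to the ring. With the shared core and the rest of the chain kept, a step of a 2.0-fold higher number from compound 2 to compound 3 (0.30 log units; within the scatter) is expected, a small weakening at most and not clearly beyond the scatter. Compound 3 is therefore estimated at 2 nM, with a range from 0.6 nM to 7 nM.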

Compound 3, half-maximal inhibitory concentration: 0.6 nM
Compound 3: middle estimate off by 3.3-fold (0.52 log units), on the high side; low and high end bracket the measured number.
By their numbers in this assay, from the lowest: compounds 3, 1 and 2 (each within the scatter of the next).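

In this assay, on a saturated chain carbon bound to a saturated ring carbon, 1-phenylethyl in place of 4-fluorobenzyl gives a 1.7-fold lower number from compound 2 to compound 3 (0.22 log units; within the scatter) and in place of 3-fluorobenzyl gives a 1.2-fold lower number from compound 1 to compound 3 (0.07 log units; within the scatter), so both steps read as level. The earlier pair varied only where the fluorine sat on the ring, whereas these steps show that this place accepts a group with no fluorine and with a branched chain carbon, with no change beyond the scatter. Nothing measured accounts for this level reading.

Fluorine loss and branching arrive together in these steps, so the share of each remains unresolved. Also open, on these data alone, is how this place responds to a primary amine, a carboxylic acid or a longer chain in place of 1-phenylethyl.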